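Swapping a thienyl for a methylphenyl group on a shared core

This account rests on a few compounds, and the source may have more. Where it says the series, first, only, none or still open, it means among the compounds named here.

Of the compounds shown here, three built on the same core have been measured in a physicochemical assay for lipophilicity, using the shake flask method, in phosphate buffer, measured as octanol-water partition, with a stated time of 85 min, at pH 7.4; a lower number here means a more polar compound, a higher number a more lipophilic compound. Compound 1 `c1ccc2c(-c3cn4ccnc4c(-c4ccc5ncn(C6CCCCC6)c5c4)n3)cccc2c1` gives 1.44, compound 2 `Fc1ccc(-c2cn3ccnc3c(-c3ccc4ncn(C5CCCCC5)c4c3)n2)cc1` gives 2.01, and compound 3 `c1cn2cc(-c3ccsc3)nc(-c3ccc4ncn(C5CCCCC5)c4c3)c2n1` gives 1.81. Compound 3 thus stands second highest of the three: a number 0.20 log units lower from compound 2 to compound 3 (within the scatter), whereas a number 0.37 log units higher from compound 1 to compound 3 (beyond the scatter). Compound 4 `Cc1cccc(-c2cn3ccnc3c(-c3ccc4ncn(C5CCCCC5)c4c3)n2)c1` differs from compound 3 by 3-methylphenyl in place of thiophen-3-yl on an aromatic carbon. Among the measured compounds shown here, no measured step covers this exact exchange; the closest guide is the small step between compound 2 and compound 3 already noted, and compound 2, carrying a six-membered carbon ring, gives 2.01. A modest rise for compound 4 is therefore expected, a number 0.29 log units higher from compound 3 to compound 4 (within the scatter). Compound 4 is estimated at 2.1, within a range from 1.7 to 2.5.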

Compound 4, partition coefficient: 1.87
Compound 4: the middle estimate sits 0.23 log units above what was measured; measured number inside the range.
By their numbers in this assay, from the lowest: compound 1; then compounds 3, 4 and 2 (each within the scatter of the next).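

In this assay, the exchange of thiophen-3-yl for 3-methylphenyl on this aromatic carbon leaves the number within the scatter (a number 0.06 log units higher from compound 3 to compound 4 (within the scatter)), and the same holds for 3-methylphenyl against 4-fluorophenyl (a number 0.14 log units lower from compound 2 to compound 4 (within the scatter)). Only naphthalen-1-yl stands apart (a number 0.43 log units higher from compound 1 to compound 4 (beyond the scatter)), so the three single-ring groups cannot be told apart here, while compound 1 lies lower than each of them. No measurement at hand accounts for this. The compounds shown leave open whether an amine or a carboxylic acid on this aromatic carbon would move the number beyond the scatter of these three.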